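Replacing the phenol with a nitrophenyl group on the thiosemicarbazone

A few compounds are considered here, and "the series" means these few. Any claim that something is new, unique, unknown or untested is made for them only; others in the source may bear on it.

The first compound, compound 1 `CC1=CC[C@@H]([C@@](C)(O)CCCC(C)(C)NC(=S)N/N=C\c2ccc(C)cc2)CC1`, was tested in a functional assay on NCI-H460 cells (Homo sapiens) for cytotoxicity, read by sulforhodamine B assay; a higher number here means a weaker inhibitor of growth, a lower number a stronger inhibitor of growth. In this assay compound 1 gives only a limit, > 100000 nM, and not a number. Compound 2 `CC1=CC[C@@H]([C@@](C)(O)CCCC(C)(C)NC(=S)N/N=C\c2ccc(O)cc2)CC1` differs by a hydroxy in place of methyl on an aromatic carbon, and in this assay compound 2 gives 20700 nM. That is an at least 4.8-fold lower number from compound 1 to compound 2 (0.68 log units; beyond the scatter). Among the two values shown, compound 2 holds the only number; the other value is a limit, namely (the limit of > 100000 nM in this assay, at which 1 of the 2 values shown sits).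

Compound 3 `CC1=CC[C@@H]([C@@](C)(O)CCCC(C)(C)NC(=S)N/N=C\c2cccc([N+](=O)[O-])c2)CC1` is not yet measured. It differs from compound 2 by 3-nitrophenyl in place of 4-hydroxyphenyl on a carbon with a double bond to nitrogen. Within the data shown here, the single measured step bears on it indirectly: adding the hydroxy gave the gain seen from compound 1 to compound 2, and compound 3 gives that hydroxy up while bringing in a nitro group at another place on the ring. A step back toward weaker growth inhibition is therefore expected, of modest size and possibly reaching the limit again. Compound 3 is expected to give about 60000 nM in this assay, within 20000 nM to 150000 nM, an estimated 2.9-fold higher number from compound 2 to compound 3 (0.46 log units; beyond the scatter).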

Compound 3, concentration for total growth inhibition: 68600 nM
The estimate for compound 3 lay 1.1-fold (0.06 log units) below the measured number; the measured number falls inside the stated range.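

In this assay the gain seen with the hydroxy does not carry over to every substituted phenyl on this carbon: the swap of 4-hydroxyphenyl for 3-nitrophenyl gives a 3.3-fold higher number from compound 2 to compound 3 (0.52 log units; beyond the scatter), so compound 2 has the lowest number of the three compounds. Compound 1 gives a limit and not a number: the limit of > 100000 nM in this assay, at which 1 of the 3 values shown sits. Measured against that limit, the change of 4-methylphenyl to 3-nitrophenyl is an at least 1.4-fold lower number from compound 1 to compound 3 (0.16 log units; that floor lies within the scatter), so no order can be claimed between these two compounds, and a nitro group on this ring cannot be said to help or to harm relative to the methyl compound.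

The step from compound 2 to compound 3 changes both the group on the ring and its place there, as the names 4-hydroxyphenyl and 3-nitrophenyl show, so these compounds cannot tell which of the two changes accounts for the higher number. They also leave open how this position would respond to an amine or a carboxylic acid on the ring.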